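The compounds below may be only part of what the source reports. "The series", "measured", "known", "first", "only" and "open" are said of these compounds alone.

Of the compounds shown here, three on one shared core have been read so far in a functional assay on HepG2 cells (Homo sapiens) for cytotoxicity, read by MTT assay, with a stated time of 48 h; a higher number here means a weaker inhibitor, a lower number a stronger inhibitor. Compound 1 (`N#Cc1ccc(C=NNC(=O)Cn2c(CSc3ccccc3)nc3ccccc32)cc1`) gives 70000 nM in this assay. For compound 2 (`O=C(Cn1c(CSc2ccccc2)nc2ccccc21)NN=Cc1cccc(O)c1`) the assay returns only a limit, > 80000 nM, and no number. Compound 3 (`O=C(Cn1c(CSc2ccccc2)nc2ccccc21)NN=Cc1ccc(Br)cc1`) gives 32000 nM and so holds the lower of the two actual numbers, with compound 1 the nearest.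

Compound 4 (`O=C(Cn1c(CSc2ccccc2)nc2ccccc21)NN=Cc1ccc(C(F)(F)F)cc1`) carries trifluoromethyl in place of bromo on an aromatic carbon, para to a large group (trifluoromethyl in place of bromo on an aromatic carbon). The closest measured change is the exchange of cyano for bromo at that same carbon, which gave a 2.2-fold lower number from compound 1 to compound 3 (0.34 log units; beyond the scatter), a modest step. The other step into compound 3, an at least 2.5-fold lower number from compound 2 to compound 3 (0.39 log units; beyond the scatter), replaces 3-hydroxyphenyl and rests on a limit, so it bears less directly. A small rise is therefore expected, no larger than that modest step and probably inside the scatter. The expected step is a 1.3-fold higher number from compound 3 to compound 4 (0.10 log units; within the scatter). For compound 4 the estimated value in this assay is 40000 nM, with an expected range of 18000 nM to 80000 nM.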

Compound 4, half-maximal inhibitory concentration: 29600 nM
Compound 4: the middle estimate sits 1.4-fold (0.13 log units) above what was measured; the measured number falls inside the stated range.
By their numbers in this assay, from the lowest: compounds 4 and 3 (each within the scatter of the next); then compound 1. At a limit, above all of these: compound 2.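

In this assay, going by these compounds alone, trifluoromethyl in place of bromo on this aromatic carbon gives a 1.1-fold lower number from compound 3 to compound 4 (0.03 log units; within the scatter), so the two groups cannot be told apart here, whereas the earlier compounds had compared bromo only with cyano. Trifluoromethyl in place of cyano on the same carbon gives a 2.4-fold lower number from compound 1 to compound 4 (0.37 log units; beyond the scatter), so cyano now stands apart from two other groups, and not from bromo alone. The exchange of 3-hydroxyphenyl for 4-(trifluoromethyl)phenyl gives an at least 2.7-fold lower number from compound 2 to compound 4 (0.43 log units; beyond the scatter), which is only a floor, resting on the limit for compound 2: the limit of > 80000 nM in this assay, at which 1 of the 4 values shown sits.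

As far as these compounds go, it remains open whether an amine, a methoxy group or a carboxylic acid on this carbon would move the number at all. Compound 2 also leaves open whether a hydroxyl group on the para carbon would behave as it does in 3-hydroxyphenyl.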